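Halogen-Swapped Phenyl Analogue Assessed for Vero Cell Cytotoxicity

This account rests on a few compounds, and the source may have more. Where it says the series, first, only, none or still open, it means among the compounds named here.

Compound 3 `C[C@]1(CN2CCc3nc(-c4ccc(C(F)(F)F)cc4)ccc3C2)Cn2cc([N+](=O)[O-])nc2O1` carries a 4-(trifluoromethyl)phenyl group on the shared core. In an ADME assay on Vero cells (Chlorocebus sabaeus) for cytotoxicity, read by MTT assay, with a stated time of 72 h (a higher number here means that more compound is tolerated, a lower number that less compound is tolerated), compound 3 gives > 32 ug/mL, which is a limit of the assay and not a number. Its closest measured relative is compound 2 `C[C@]1(CN2CCc3nc(-c4cccc(F)c4)ccc3C2)Cn2cc([N+](=O)[O-])nc2O1`. In this assay compound 2 gives > 32 ug/mL, again a limit. The step that the two limits leave unreadable from compound 2 to compound 3 therefore cannot be sized, because both values sit at the limit of > 32 ug/mL in this assay, at which 2 of the 3 values shown sit. A third member, compound 1 `C[C@]1(CN2CCc3nc(C(F)(F)F)ccc3C2)Cn2cc([N+](=O)[O-])nc2O1`, has "not determined" (no result reported) in this assay. Among the measured compounds shown here, compound 3 thus stands at the same limit as the only other compound with a result, and no ordering can be read.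

For the measured compounds named here, compound 4 `C[C@]1(CN2CCc3nc(-c4cc(F)ccc4Cl)ccc3C2)Cn2cc([N+](=O)[O-])nc2O1` is the unmeasured analogue. 2-chloro-5-fluorophenyl in place of 4-(trifluoromethyl)phenyl on an aromatic carbon The one step that bears on this change, from compound 2 to compound 3, was unreadable, with both values at the limit of > 32 ug/mL in this assay, at which 2 of the 3 values shown sit. Compound 4 is therefore expected to show a step that the limit leaves unreadable from compound 3 to compound 4 that stays within the scatter, most probably ending at another limit. Compound 4 is estimated in this assay at 40 ug/mL, with a range from 20 ug/mL to 80 ug/mL.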

Compound 4, half-maximal cytotoxic concentration: > 32 ug/mL
Compound 4: only a limit was reported (the forecaster's own chance of this, stated with the estimate: 75%); the middle value lies beyond the limit too.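

In this assay, the steps among compound 2, compound 3 and compound 4 cannot be read, since all three results are limits: the limit of > 32 ug/mL in this assay, at which 3 of the 4 values shown sit. The compounds shown leave open how far each tolerated concentration lies past that limit, and whether the groups exchanged on the shared core make any difference.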